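The compounds below may be only part of what the source reports. "The series", "measured", "known", "first", "only" and "open" are said of these compounds alone.

Measured so far:
- compound 1 `O=C(NCc1ccc(S(=O)(=O)C2CCOCC2)cc1)N1Cc2ccncc2C1`: 35 nM
- compound 2 `CCC(=O)N1CCC(S(=O)(=O)c2ccc(CNC(=O)N3Cc4ccncc4C3)cc2)CC1`: 54 nM

In a functional assay on A2780 cells (Homo sapiens) for cytotoxicity, read by sulforhodamine B assay, with a stated time of 72 h (on this read-out higher numbers stand for weaker inhibition and lower numbers for stronger inhibition), compound 2 gives 54 nM, within the scatter of compound 1, so the two carry no order. Not yet measured is compound 3 `CN1CCN(S(=O)(=O)c2ccc(CNC(=O)N3Cc4ccncc4C3)cc2)CC1`, with 4-methylpiperazin-1-yl in place of 1-propanoylpiperidin-4-yl on a sulfonyl sulfur. For the measured compounds named here, only one measured step bears on this place, a 1.5-fold higher number from compound 1 to compound 2 (0.19 log units; within the scatter), and it is small. No change beyond the scatter is therefore expected in this assay, though one step is thin evidence. The expected step is a 1.3-fold higher number from compound 2 to compound 3 (0.11 log units; within the scatter). For compound 3 the estimated value is 70 nM, with an expected range of 25 nM to 200 nM.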

Compound 3, half-maximal inhibitory concentration: 71 nM
Compound 3: middle estimate off by 1.0-fold (0.01 log units), on the low side, within the range that was stated.
By their numbers in this assay, from the lowest: compounds 1, 2 and 3 (each within the scatter of the next, the first and the last beyond it).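

In this assay the sulfonyl sulfur carries 4-methylpiperazin-1-yl in place of 1-propanoylpiperidin-4-yl with no separable change (a 1.3-fold higher number from compound 2 to compound 3 (0.12 log units; within the scatter)). Set against oxan-4-yl, however, 4-methylpiperazin-1-yl gives the only step at this place beyond the scatter, a modest one (a 2.0-fold higher number from compound 1 to compound 3 (0.31 log units; beyond the scatter)). Nothing measured here gives a reason for either step.

All three compounds carry a six-membered non-aromatic ring on the sulfonyl sulfur. Open, as far as these compounds go, is whether an open-chain amine or a carboxylic acid there would hold the number in this range.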